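The source may hold more compounds than are shown below. What is called first, only, known or untested is meant among the compounds shown, and "the series" means these compounds.

Measured so far in an ADME assay on LLC-MK2 cells (Macaca mulatta) for cytotoxicity, read by spectrophotometry and crystal violet staining, with a stated time of 4 days; on this read-out higher numbers stand for lower toxicity in this test and lower numbers for higher toxicity in this test:
Compound 1 `CC(C)n1ncc2c(C(=O)Nc3cccc(F)c3F)cc(-c3cccs3)nc21` gives 75000 nM.
Compound 2 `CC(C)n1ncc2c(C(=O)Nc3ccc(F)c(F)c3)cc(-c3cccs3)nc21` reaches only a limit of the test, > 200000 nM.
Compound 3 `CC(C)n1ncc2c(C(=O)Nc3ccccc3F)cc(-c3cccs3)nc21` gives 50000 nM.

Of the two plain numbers, compound 3 holds the lower one, with compound 1 nearest; the gap between them, a 1.5-fold lower number from compound 1 to compound 3 (0.18 log units; within the scatter), sits within the scatter, so the two cannot be placed in order. The third value is a limit only.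

Compound 4 `CC(C)n1ncc2c(C(=O)Nc3ncccn3)cc(-c3cccs3)nc21` differs from compound 3 on the amide-type nitrogen: pyrimidin-2-yl in place of 2-fluorophenyl on an amide-type nitrogen. Within the data shown here, two measured steps touch the same ring. One, a 1.5-fold lower number from compound 1 to compound 3 (0.18 log units; within the scatter), stays within the scatter; the other, an at least 4.0-fold lower number from compound 2 to compound 3 (0.60 log units; beyond the scatter), shows that rearranging fluorine on this ring can move the number beyond it. Among the measured compounds shown here, neither step exchanges the all-carbon ring for a ring with hetero atoms, so no measured step mirrors this change directly. What the steps do show is that alterations at this ring have moved the number by a modest amount at most.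

Compound 4 is therefore expected to land near compound 3, at an estimated 80000 nM, between 30000 nM and 200000 nM. The step this estimate implies for compound 4, a 1.6-fold higher number from compound 3 to compound 4 (0.20 log units; within the scatter), is expected to stay within the scatter.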

Compound 4, half-maximal cytotoxic concentration: 75000 nM
The estimate for compound 4 lay 1.1-fold (0.03 log units) above the measured number, and the stated range covers the measured number.
By their numbers in this assay, from the lowest: compounds 3, 1 and 4 (each within the scatter of the next). At a limit, above all of these: compound 2.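

Among these compounds, the earlier compounds varied only the fluorine on an all-carbon ring, whereas compound 4 is the first here to carry a ring with hetero atoms, pyrimidin-2-yl, on the amide-type nitrogen. In this assay, this exchange gives a 1.5-fold higher number from compound 3 to compound 4 (0.18 log units; within the scatter) and no change at the digits printed from compound 1 to compound 4 (within the scatter), so the new ring cannot be told apart from either of these two fluorinated rings. That leaves one separation, an at least 2.6-fold lower number from compound 2 to compound 4 (0.42 log units; beyond the scatter), and it starts from a limit of the test, not a number: the limit of > 200000 nM in this assay, at which 1 of the 4 values shown sits.

The compounds shown leave open whether the ring nitrogens of pyrimidin-2-yl matter at all, as neither pyridin-2-yl, with a single ring nitrogen, nor plain unsubstituted phenyl is among them. Also open, going by these compounds, is whether a phenyl ring carrying an amine or a carboxylic acid, or a saturated ring such as piperidine, on the amide-type nitrogen would stay within the scatter of compound 4 in this assay.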